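Moving the methoxy group on a thiosemicarbazone anilide

The compounds below may be only part of what the source reports. "The series", "measured", "known", "first", "only" and "open" are said of these compounds alone.

Compound 1 `COc1cccc(NC(=S)N/N=C/c2ccc3ccccc3n2)c1`: 71200 nM
Compound 2 `NC(=S)N/N=C/c1cnc2ccccc2n1`: > 100000 nM
Compound 3 `Cc1ccc(NC(=O)N/N=C/c2ccc3ccccc3n2)cc1`: > 100000 nM

Among the measured compounds shown here, in a functional assay on HL-60 cells (Homo sapiens) for antiproliferative activity, read by sulforhodamine B assay, with a stated time of 72 h (a higher number here means a weaker inhibitor, a lower number a stronger inhibitor), compound 1 gives 71200 nM, the only actual number among the three results. For compound 2 the result is a limit of the assay, > 100000 nM. For compound 3 the result is likewise a limit, > 100000 nM. For the measured compounds named here, compound 1 thus stands alone as the one compound with a measurable value, while two of the three results sit at the limit of > 100000 nM in this assay, at which 2 of the 3 values shown sit. No two of these compounds differ in a single place, so no measured step can be drawn from them.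

Compound 4 `COc1ccc(NC(=S)N/N=C/c2ccc3ccccc3n2)cc1` is yet to be tested. It differs from compound 1 in this way: 4-methoxyphenyl in place of 3-methoxyphenyl on an amide-type nitrogen. Going by the values given here, with no measured step to lean on, this change is expected to give a step in this assay no larger than the usual scatter, in no clear direction. Compound 4 is therefore estimated at 80000 nM, between 30000 nM and 200000 nM. The expected step is a 1.1-fold higher number from compound 1 to compound 4 (0.05 log units; within the scatter). Because two results already sit at the limit of > 100000 nM in this assay, at which 2 of the 3 values shown sit, there is a fair chance that compound 4 also returns only a limit.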

Compound 4, half-maximal inhibitory concentration: 43800 nM
Compound 4: middle estimate off by 1.8-fold (0.26 log units), on the high side; the measured number falls inside the stated range.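

In this assay, among the compounds shown here, the exchange of 3-methoxyphenyl for 4-methoxyphenyl on the amide-type nitrogen gives the only single change that can be read here: a 1.6-fold lower number from compound 1 to compound 4 (0.21 log units; within the scatter). This shift of the methoxy group therefore does not move the result beyond the usual scatter, and the two compounds cannot be ranked against each other. Both carry actual numbers, whereas compound 2 and compound 3 remain limits of the assay rather than numbers: the limit of > 100000 nM in this assay, at which 2 of the 4 values shown sit.

The compounds shown leave open whether a different group on this phenyl ring, such as an amine or a carboxylic acid, would produce a step beyond the scatter. They also leave open what the thiocarbonyl contributes, as no pair shown differs in that place alone.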